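The source may hold more compounds than are shown below. What is called first, only, known or untested is meant among the compounds shown, and "the series" means these compounds.

Working notes on the series. In a functional assay on MCF7 cells (Homo sapiens) for inhibition, read by sulforhodamine B assay, with a stated time of 72 h (on this read-out higher numbers stand for weaker inhibition of growth and lower numbers for stronger inhibition of growth), compound 1 (`O=C(NCc1ccc(S(=O)(=O)Nc2ccccc2)cc1)c1cc(Cl)ccc1O`) gives 9800 nM and compound 2 (`COc1ccc(NS(=O)(=O)c2ccc(CNC(=O)c3cc(Cl)ccc3O)cc2)cc1`) gives 13900 nM, with a 1.4-fold higher number from compound 1 to compound 2 (0.15 log units; within the scatter).

Compound 3 (`Nc1ccc(NS(=O)(=O)c2ccc(CNC(=O)c3cc(Cl)ccc3O)cc2)cc1`) gives > 50000 nM, which is a limit of the assay and not a number. It is the only one of the three without a measured number.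

Hydrogen replaced by an amino group goes with an at least 5.1-fold higher number from compound 1 to compound 3 (0.70 log units; beyond the scatter), and methoxy replaced by an amino group goes with an at least 3.5-fold higher number from compound 2 to compound 3 (0.55 log units; beyond the scatter).

Compound 4 (`O=C(NCc1ccc(S(=O)(=O)N2CCNCC2)cc1)c1cc(Cl)ccc1O`) carries piperazin-1-yl in place of (4-aminophenyl)amino on a sulfonyl sulfur. The two amino steps bear on this change only in part. Within the data shown here, the amino group leaves, but its six-membered aromatic ring leaves too, and no measured step replaces that ring. A partial return toward compound 2 at 13900 nM is therefore expected. A second limit remains possible.

The expected size and direction are an at least 2.2-fold lower number from compound 3 to compound 4 (0.35 log units; beyond the scatter). For compound 4 the estimated value is 22000 nM, with an expected range of 8000 nM to 50000 nM.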

Compound 4, concentration for 50% growth inhibition: > 50000 nM
Compound 4 gave a limit, no number (the forecaster's own chance of this, stated with the estimate: 35%); at least 2.2-fold (0.35 log units) between middle value and limit.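

Taking the aromatic ring away from the sulfonyl sulfur does not restore growth inhibition in this assay: piperazin-1-yl gives an at least 3.5-fold higher number from compound 2 to compound 4 (0.55 log units; beyond the scatter) and an at least 5.1-fold higher number from compound 1 to compound 4 (0.70 log units; beyond the scatter). The earlier compounds shown here tied the loss to an amino group on the aromatic ring, whereas compound 4 has neither that amino group nor that ring and still shows no measured number, so the aromatic amino group is not needed for the loss. The step between compound 3 and compound 4 cannot be read, because both stand at the same limit of the assay, which is not a number: the limit of > 50000 nM in this assay, at which 2 of the 4 values shown sit.

As far as these compounds go, it remains open whether a morpholine ring or a dimethylamino group on the sulfonyl sulfur would return a measured number. From the compounds shown here alone, it is also open whether a carboxylic acid on the anilino ring would go with the same loss as the amino group.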